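Benzothiazole in place of benzoxazole on the shared core

The source may hold more compounds than are shown below. What is called first, only, known or untested is meant among the compounds shown, and "the series" means these compounds.

Within the data shown here, compound 2 `CCN(CC)c1nc(Nc2ccc3ncoc3c2)nc(OC(C(F)(F)F)C(F)(F)F)n1` holds the lowest of the two numbers measured so far in an assay on cells for activation of Cystic fibrosis transmembrane conductance regulator (Homo sapiens), read by fluorescence, with stated times of 10 min and 12 s (on this read-out lower numbers stand for an effect already at smaller amounts and higher numbers for an effect only at larger amounts of compound), giving 150 nM. Among the measured compounds shown here, its nearest neighbour is compound 1 `CCN(CC)c1nc(Nc2ccc3cn[nH]c3c2)nc(OC(C(F)(F)F)C(F)(F)F)n1`, which gives 900 nM in this assay; the only measured step, a 6.0-fold lower number from compound 1 to compound 2 (0.78 log units; beyond the scatter), exchanged the indazolyl group for the benzoxazolyl group on the nitrogen attached to the aromatic core. Compound 3 `CCN(CC)c1nc(Nc2ccc3ncsc3c2)nc(OC(C(F)(F)F)C(F)(F)F)n1` differs from compound 2 by 1,3-benzothiazol-6-yl in place of 1,3-benzoxazol-6-yl on a nitrogen on an aromatic ring. For the measured compounds named here, no measured step bears directly on this exchange: the step from compound 1 to compound 2 replaced one bicyclic group by another of different ring type, whereas here the bicyclic group keeps its shape and only the heteroatom in the five-membered ring changes. Without a comparable precedent, a step of modest size at most is expected, in either direction, most likely within the scatter. For compound 3 the half-maximal effective concentration in this assay is estimated at 150 nM, with a range from 50 nM to 500 nM. This estimate corresponds to no change at the digits printed from compound 2 to compound 3 (within the scatter).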

Compound 3, half-maximal effective concentration: 50 nM
Beside the measured number, compound 3's estimate is 3.0-fold (0.48 log units) above it; low and high end bracket the measured number.
By their numbers in this assay, from the lowest: compound 3; then compound 2; then compound 1.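

In this assay, a change of only the heteroatom in the five-membered ring, 1,3-benzothiazol-6-yl in place of 1,3-benzoxazol-6-yl, gives a 3.0-fold lower number from compound 2 to compound 3 (0.48 log units; beyond the scatter), so this position on the nitrogen responds even where the bicyclic shape is kept. Taken over the whole exchange, 1,3-benzothiazol-6-yl in place of 1H-indazol-6-yl gives an 18-fold lower number from compound 1 to compound 3 (1.26 log units; beyond the scatter), which makes the choice of bicyclic group at this position a large lever among the three compounds. Nothing on hand accounts for the order of these three groups.

Open, from the compounds shown here alone, is whether a methyl group or a chlorine atom on the 1,3-benzothiazol-6-yl group keeps the number of compound 3. Also open, going by these compounds, is where a plain phenyl group on the same nitrogen would fall in this order.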